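The source may report more compounds than this note shows. Statements on the series, on what has been measured and on what is new or still open speak of the compounds shown alone.

Three compounds have been measured in an ADME assay (liver) for pharmacokinetics, with Liver microsome (Rattus norvegicus) as the target, read by LC-MS, using microsomes, tested at 2 uM; a higher number here means faster removal of the compound, a lower number slower removal:

Compound 1 `O=C(N[C@@H]1CCCC[C@H]1O)c1cnc(OC2CCCCC2)c(-c2ccc(Cl)cc2)c1` gives 0.662 mL/min/kg
Compound 2 `O=C(N[C@@H]1CCCC[C@H]1O)c1cnc(OC2CCC2)c(-c2ccc(Cl)cc2)c1` gives 0.21 mL/min/kg
Compound 3 `COCCOc1ncc(C(=O)N[C@@H]2CCCC[C@H]2O)cc1-c1ccc(Cl)cc1` gives 0.098 mL/min/kg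

Compound 1 has the highest of these three numbers, so it is removed fastest. The nearest to it is compound 2, reached by a step of a 3.2-fold lower number from compound 1 to compound 2 (0.50 log units; beyond the scatter). The furthest is compound 3, reached by a step of a 6.8-fold lower number from compound 1 to compound 3 (0.83 log units; beyond the scatter). Compound 4 `Cc1cc(COc2ncc(C(=O)N[C@@H]3CCCC[C@H]3O)cc2-c2ccc(Cl)cc2)on1` is the untested compound; relative to compound 1 its change is (3-methyl-1,2-oxazol-5-yl)methyl in place of cyclohexyl on an oxygen on an aromatic ring. Both measured steps also replace the cyclobutyl at this oxygen, and both lowered the number in this assay by a modest amount, so a modest drop is expected here too, roughly a 3.7-fold lower number from compound 1 to compound 4 (0.57 log units; beyond the scatter). Compound 4 is therefore estimated at 0.18 mL/min/kg, within a range from 0.07 mL/min/kg to 0.45 mL/min/kg.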

Compound 4, clearance: 0.151 mL/min/kg
Compound 4: the middle estimate sits 1.2-fold (0.08 log units) above what was measured; low and high end bracket the measured number.
By their numbers in this assay, from the lowest: compounds 3, 4 and 2 (each within the scatter of the next, the first and the last beyond it); then compound 1.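

In this assay an aromatic ring also fits at this oxygen: (3-methyl-1,2-oxazol-5-yl)methyl in place of cyclohexyl still lowers the number (a 4.4-fold lower number from compound 1 to compound 4 (0.64 log units; beyond the scatter)). This group sits level with both saturated replacements, the chain 2-methoxyethyl (a 1.5-fold higher number from compound 3 to compound 4 (0.19 log units; within the scatter)) and the ring cyclobutyl (a 1.4-fold lower number from compound 2 to compound 4 (0.14 log units; within the scatter)). Compound 2, compound 3 and compound 4 therefore cannot be told apart as a set, yet each lies beyond the scatter from compound 1. From the compounds shown here alone, whether an amine or a carboxylic acid at this oxygen would behave the same remains open. Nothing at hand gives a reason for these steps.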